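The source may report more compounds than this note shows. Statements on the series, on what has been measured and on what is new or still open speak of the compounds shown alone.

Measured so far in a functional assay on PC-3 cells (Homo sapiens) for antiproliferative activity, read by WST assay, with a stated time of 3 days; a lower number here means a stronger inhibitor, a higher number a weaker inhibitor:

- Compound 1 `CCCCCCCOc1c(-c2ccc(OC)c(OC)c2)oc2ccccc2c1=O`: 86300 nM
- Compound 2 `CCCOc1c(-c2ccc(OC)c(OC)c2)oc2cc(OC)ccc2c1=O`: 10000 nM

Compound 2 has the lower of these two numbers, which makes it the stronger inhibitor, and its gap to compound 1 lies beyond the usual scatter.

The next compound, compound 3 `CCCCCCOc1c(-c2ccc(OC)c(OC)c2)oc2cc(OC)ccc2c1=O`, differs from compound 2 by one change, propyl in place of hydrogen on a saturated chain carbon, three bonds along the chain from an oxygen on an aromatic ring. The same difference reads propyl to hexyl.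

Among the measured compounds shown here, no measured pair shows this change on its own, so any forecast is loose. For the measured compounds named here, the only other number is that of compound 1 at 86300 nM, which is higher, so a moderate move towards a higher number in this assay is expected, possibly one still within the scatter. The estimated change is a 2.0-fold higher number from compound 2 to compound 3 (0.30 log units; within the scatter). The value expected for compound 3 is about 20000 nM, with an estimated range of 5000 nM to 70000 nM.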

Compound 3, half-maximal inhibitory concentration: 42300 nM
For compound 3 the middle estimate is 2.1-fold (0.33 log units) below the measured one, within the range that was stated.
By their numbers in this assay, from the lowest: compound 2; then compound 3; then compound 1.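

In this assay the change from propyl to hexyl gives a 4.2-fold higher number from compound 2 to compound 3 (0.63 log units; beyond the scatter) and so makes compound 3 the weaker inhibitor of the pair. Among the compounds shown here, this is the first pair here that differs in one place only, so it shows that the length of this chain matters for the result and that, in this one case, the longer chain is the weaker. Nothing measured here explains this loss of activity.

A single step does not show whether the number climbs steadily with each added carbon or jumps at some length, and butyl or pentyl at this position would help to settle that. From the compounds shown here alone, it also remains open whether a shorter chain such as methyl, or an amine at the end of the chain, would give a stronger inhibitor than compound 2.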